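Swapping the sulfonyl substituent in a pyridopyrimidinone series

A few compounds are considered here, and "the series" means these few. Any claim that something is new, unique, unknown or untested is made for them only; others in the source may bear on it.

Measured compounds:
Compound 1, `Cn1c(=O)c(S(=O)(=O)c2ccc(F)cc2F)cc2cnc(Nc3ccc4cc[nH]c4c3)nc21`: 5000 nM
Compound 2, `Cn1c(=O)c(S(=O)(=O)Cc2ccc(F)cc2)cc2cnc(Nc3ccc4[nH]ccc4c3)nc21`: 30000 nM
Compound 3, `COc1ccc(Nc2ncc3cc(S(=O)(=O)c4ccc(C)cc4)c(=O)n(C)c3n2)cc1`: 100000 nM

In a functional assay on DU-145 cells (Homo sapiens) for inhibition, read by trypan blue exclusion, with a stated time of 72 h (on this read-out lower numbers stand for stronger inhibition and higher numbers for weaker inhibition), compound 2 gives 30000 nM, which stands second highest of the three numbers. Compound 3 sits further up, beyond the scatter, while compound 1 sits below it, also beyond the scatter. Compound 4, `COc1ccc(S(=O)(=O)c2cc3cnc(Nc4ccc5[nH]ccc5c4)nc3n(C)c2=O)cc1`, has not yet been measured. It differs from compound 2 in one place: 4-methoxyphenyl in place of 4-fluorobenzyl on a sulfonyl sulfur. Among the compounds with values here, no directly comparable pair among the measured compounds isolates this change, so the expectation rests on the spread of the three values alone. A modest shift toward stronger inhibition is expected, with the step of a 2.0-fold lower number from compound 2 to compound 4 (0.30 log units; within the scatter). Compound 4 is therefore estimated at 15000 nM, with a range from 4000 nM to 60000 nM.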

Compound 4, half-maximal inhibitory concentration: 500 nM
Estimate against measurement, compound 4: 30-fold (1.48 log units) above, and the stated range ends above it.
By their numbers in this assay, from the lowest: compound 4; then compound 1; then compound 2; then compound 3.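

In this assay, the group on the sulfonyl sulfur matters greatly: 4-methoxyphenyl in place of 4-fluorobenzyl gives a 60-fold lower number from compound 2 to compound 4 (1.78 log units; beyond the scatter). Within the data shown here, this is the first pair that isolates a change at this position, and the swap alters both the link to the sulfur and the substituent on the ring. No measurement shown explains the step.

From the compounds shown here alone, whether 4-fluorophenyl or 4-methoxybenzyl would behave like compound 4 stays open, so the two parts of the swap cannot be told apart. Going by these compounds, how an amine or a carboxylic acid on that ring would fare is also open.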